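The compounds below may be only part of what the source reports. "The series", "measured", "known", "first", "only" and "open" are said of these compounds alone.

Compound 1 `CC(=O)Oc1ccc(/C=C/C(=O)NCCCSc2nc(-c3ccc(S(C)(=O)=O)cc3)n(-c3ccc(Br)cc3)n2)cc1OC(C)=O` and compound 2 `CC(=O)Oc1ccc(/C=C/C(=O)NCCCSc2nc(-c3ccc(S(C)(=O)=O)cc3)n(-c3ccc(F)cc3)n2)cc1OC(C)=O` share one core, while compound 3 `COc1cc(/C=C/C(=O)OCCSc2nc(-c3ccc(S(C)(=O)=O)cc3)n(-c3ccc(Br)cc3)n2)ccc1OC(C)=O` and compound 4 `COc1cc(/C=C/C(=O)OCCSc2nc(-c3ccc(S(C)(=O)=O)cc3)n(-c3ccc(F)cc3)n2)ccc1OC(C)=O` share another; the difference between the two cores is not broken down here. In a functional assay on PC-3 cells (Homo sapiens) for antiproliferative activity, read by MTT assay, with a stated time of 72 h (a higher number here means a weaker inhibitor, a lower number a stronger inhibitor), compound 1 gives 23900 nM, and compound 2 gives 17600 nM. The change between them is fluoro in place of bromo on an aromatic carbon, and it made a step of a 1.4-fold lower number from compound 1 to compound 2 (0.13 log units; within the scatter). In this assay compound 3 gives 13100 nM, a number that sits within the scatter of both compound 1 and compound 2. Compound 4 has not yet been measured. Within the data shown here, it differs from compound 3 by fluoro in place of bromo on an aromatic carbon, the same change as the one from compound 1 to compound 2, placed in the same way on the ring. Because the earlier step of a 1.4-fold lower number from compound 1 to compound 2 (0.13 log units; within the scatter) stayed within the scatter, a similarly small step is expected here, estimated as a 1.3-fold lower number from compound 3 to compound 4 (0.12 log units; within the scatter). For compound 4 in this assay the estimate is 10000 nM, with a range from 4500 nM to 22000 nM expected to hold most repeat measurements.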

Compound 4, half-maximal inhibitory concentration: 12800 nM
Compound 4: the middle estimate sits 1.3-fold (0.11 log units) below what was measured; low and high end bracket the measured number.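

In this assay, replacing 4-bromophenyl with 4-fluorophenyl gives a 1.0-fold lower number from compound 3 to compound 4 (0.01 log units; within the scatter), so on this second core too the step stays inside the normal spread of repeat measurements. Set side by side, the two steps do not differ: the same change on two cores in this assay, a 1.4-fold lower number (0.13 log units; within the scatter) from compound 1 to compound 2 and a 1.0-fold lower number (0.01 log units; within the scatter) from compound 3 to compound 4, 1.3-fold (0.12 log units) apart, within the scatter of two such steps. For these two pairs, the exchange of bromo for fluoro reads the same on both cores, but neither step can be told apart from the scatter, so this shows only that no effect was detected on either core, not that a real effect of a fixed size and direction carries over, and it says nothing about cores beyond these two.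

The compounds shown leave open what a chloro group, a methoxy group or an amine would do at the same place on the ring, where a larger step might appear. They also leave open whether the step stays this small on a core with a longer chain or with a carboxylic acid in place of the acetate esters.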